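This account rests on a few compounds, and the source may have more. Where it says the series, first, only, none or still open, it means among the compounds named here.

Of the compounds shown here, three that share one core have been measured in an assay on isolated protein for inhibition of Fatty-acid amide hydrolase 1 (Homo sapiens); a higher number here means a weaker inhibitor, a lower number a stronger inhibitor. Compound 1 `O=C(CCCC1CCN(C(=O)C2CCCCC2)CC1)c1ncco1` gives 45 nM. Compound 2 `O=C(CCCC1CCN(S(=O)(=O)Cc2ccccc2)CC1)c1ncco1` gives 600 nM. Compound 3 `O=C(CCCC1CCN(S(=O)(=O)CCc2ccccc2)CC1)c1ncco1` gives 6 nM. Compound 1 thus stands second highest of the three numbers: compound 3 sits lower and compound 2 sits higher, and both gaps lie beyond the scatter. Compound 4 `CC(C)C(=O)N1CCC(CCCC(=O)c2ncco2)CC1` has not yet been measured; it differs from compound 1 by isopropyl in place of cyclohexyl on a carbonyl carbon. Among the measured compounds shown here, the only step measured between two compounds that differ in one place is a 100-fold lower number from compound 2 to compound 3 (2.00 log units; beyond the scatter), which concerns the chain attached to a sulfonyl sulfur rather than the group on the amide carbonyl, so it bears on the present change only in showing that altering the group on this side of the core can shift the number strongly. Nothing measured here shows directly what replacing cyclohexyl with isopropyl does. A moderate weakening is expected, a 3.3-fold higher number from compound 1 to compound 4 (0.52 log units; beyond the scatter). Compound 4 is therefore estimated at 150 nM, with a range from 40 nM to 600 nM.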

Compound 4, half-maximal inhibitory concentration: 250 nM
Beside the measured number, compound 4's estimate is 1.7-fold (0.22 log units) below it; low and high end bracket the measured number.
By their numbers in this assay, from the lowest: compound 3; then compound 1; then compound 4; then compound 2.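

Among the compounds shown here, replacing cyclohexyl with isopropyl on the carbonyl carbon gives a 5.6-fold higher number from compound 1 to compound 4 (0.74 log units; beyond the scatter) in this assay, the first direct reading of a change at this position, since the earlier step concerned the chain on a sulfonyl sulfur. The group on this amide carbonyl therefore affects the number, and in this single pair the ring of six carbons goes with the stronger inhibitor and the three-carbon isopropyl with the weaker one. No available evidence explains why the number moves with this change.

The compounds shown leave open whether the ring itself or simply the number of carbons matters more. Phenyl, cyclopentyl, tert-butyl or a straight hexyl chain on the same carbonyl carbon would help separate those two readings.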